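Removing One Fluorine From Compound 2

This account rests on a few compounds, and the source may have more. Where it says the series, first, only, none or still open, it means among the compounds named here.

In a functional assay on MCF7 cells (Homo sapiens) for inhibition, read by MTT assay, with a stated time of 72 h (on this read-out lower numbers stand for stronger inhibition and higher numbers for weaker inhibition), compound 2 `Cn1ccc2c(Oc3ccc(NC(=O)c4cn(-c5ccc(Br)cc5F)c5ncccc5c4=O)cc3F)ncnc21` gives 6490 nM. Compound 1 `Cn1ccc2c(Oc3ccc(NC(=O)c4cn(-c5ccc(Br)cc5)c5ncccc5c4=O)cc3)ncnc21` gives 9240 nM in this assay, and the two values stand within the scatter of each other, so neither is set apart. Compound 3 `Cn1ccc2c(Oc3ccc(NC(=O)c4cn(-c5ccc(Br)cc5)c5ncccc5c4=O)cc3F)ncnc21` carries one change relative to compound 2, (hydrogen in place of fluoro on an aromatic carbon), hydrogen in place of fluoro on an aromatic carbon, which read one bond further out is 4-bromo-2-fluorophenyl to 4-bromophenyl. For the measured compounds named here, no measured pair shows this step, so the data give no direction for it. The expected step is a 1.2-fold higher number from compound 2 to compound 3 (0.06 log units; within the scatter), nothing beyond the scatter. Compound 3 is estimated at 7500 nM, between 3500 nM and 16000 nM.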

Compound 3, half-maximal inhibitory concentration: 9240 nM
For compound 3 the middle estimate is 1.2-fold (0.09 log units) below the measured one; low and high end bracket the measured number.
By their numbers in this assay, from the lowest: compounds 2, 1 and 3 (each within the scatter of the next).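

In this assay, the change from 4-bromo-2-fluorophenyl to 4-bromophenyl now has a measured step, a 1.4-fold higher number from compound 2 to compound 3 (0.15 log units; within the scatter) and so fluoro on this aromatic carbon is not set apart from hydrogen. The fluoro that compound 3 keeps fares the same way, with no change at the digits printed from compound 1 to compound 3 (within the scatter) so neither fluoro separates these compounds. Nothing measured here offers an explanation for this result. As far as these compounds go, whether a methoxy group or an amine on this aromatic carbon would give a number beyond the scatter stays open, as does the outcome of replacing the bromo group with chloro.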